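Benzyl in place of ethyl on the shared core

A few compounds are considered here, and "the series" means these few. Any claim that something is new, unique, unknown or untested is made for them only; others in the source may bear on it.

Measured so far:
compound 1, `COc1ccccc1CSc1nc2cc(NC(=O)C3CC3)ccc2n1C(C)C`, > 10000 nM
compound 2, `CCn1c(SCc2cc([N+](=O)[O-])ccc2OC)nc2cc(NC(=O)NC(C)(C)C)ccc21`, 170 nM

Of the compounds shown here, two on this core have been tested in an assay on isolated protein for inhibition of Gonadotropin-releasing hormone receptor (Rattus norvegicus); a lower number here means a stronger inhibitor, a higher number a weaker inhibitor. For compound 1 the assay returns only a limit, > 10000 nM, so no number is known for it; this is the limit of > 10000 nM in this assay, at which 1 of the 2 values shown sits. Going by the values given here, compound 2, with its tert-butyl urea and nitro-bearing methoxybenzyl sulfide, gives 170 nM in this assay, and this is the only numerical value shown, so compound 2 stands alone as the one compound with a measured potency and nothing can be said about where it ranks.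

Compound 3, `COc1ccc([N+](=O)[O-])cc1CSc1nc2cc(NC(=O)NC(C)(C)C)ccc2n1Cc1ccccc1`, keeps everything in compound 2 except for one change: phenyl in place of methyl on a saturated chain carbon bound to an aromatic nitrogen. Among the compounds with values here, no measured pair shows the effect of this change, so its size has to be guessed. The change is expected to stay near the scatter of the assay, with no strong direction, as a 1.1-fold lower number from compound 2 to compound 3 (0.05 log units; within the scatter). For compound 3 in this assay a value of 150 nM is therefore expected, within a range from 40 nM to 600 nM.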

Compound 3, half-maximal inhibitory concentration: 160 nM
Compound 3: the middle estimate sits 1.1-fold (0.03 log units) below what was measured, within the range that was stated.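

With the tert-butyl urea and the nitro-bearing methoxybenzyl sulfide held fixed, phenyl in place of methyl on a saturated chain carbon bound to an aromatic nitrogen gives a 1.1-fold lower number from compound 2 to compound 3 (0.03 log units; within the scatter) in this assay. Going by these compounds alone, this is the first pair on the shared core that differs in one place, and it shows that this position carries either ethyl or benzyl, with its six-membered aromatic ring, while the two values stay within the scatter of each other. The values shown offer nothing that explains this result.

As far as these compounds go, the comparison covers only ethyl and benzyl here, so it remains open how this position would respond to a longer chain, or to a benzyl bearing an amine or a carboxylic acid on its ring. Compound 1 gives > 10000 nM, which is a limit of the assay and not a number, and it differs from the other compounds in more than one place, so what each of its differences contributes cannot be read.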